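Aryl Swaps on the Triazole Nitrogen and Antiproliferative Potency

The compounds below may be only part of what the source reports. "The series", "measured", "known", "first", "only" and "open" are said of these compounds alone.

Measured compounds:
compound 1, `CCOc1ccc(-n2nncc2CN2C(=O)C3(C(C#N)=C(N)Oc4c(N)cc5nc6ccccc6nc5c43)c3ccccc32)cc1`, a limit only: > 50000 nM
compound 2, `Cc1cc(C)cc(-n2nncc2CN2C(=O)C3(C(C#N)=C(N)Oc4c(N)cc5nc6ccccc6nc5c43)c3ccccc32)c1`: 31200 nM

For the measured compounds named here, in a functional assay on A549 cells (Homo sapiens) for antiproliferative activity, read by MTT assay, with a stated time of 48 h (a higher number here means a weaker inhibitor, a lower number a stronger inhibitor), compound 2 gives 31200 nM, the only real number among the two values shown. For compound 1 this assay reports only (the limit of > 50000 nM in this assay, at which 1 of the 2 values shown sits). Between these two the one measured step, 3,5-dimethylphenyl in place of 4-ethoxyphenyl on an aromatic nitrogen, gave an at least 1.6-fold lower number from compound 1 to compound 2 (0.20 log units; that floor lies within the scatter), so whether compound 2 is truly stronger than compound 1 is not settled by the numbers.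

Compound 3, `COc1ccc(OC)c(-n2nncc2CN2C(=O)C3(C(C#N)=C(N)Oc4c(N)cc5nc6ccccc6nc5c43)c3ccccc32)c1`, differs from compound 2 by 2,5-dimethoxyphenyl in place of 3,5-dimethylphenyl on an aromatic nitrogen. Going by the values given here, only the step from compound 1 to compound 2 bears on this change; it shows that an alkoxy-bearing ring on this nitrogen sat at the limit while the dimethyl ring gave a measurable number, and compound 3 returns to an alkoxy-bearing ring, now with two methoxy groups. On that thin basis compound 3 is expected to give a somewhat higher number than compound 2, with a step of about a 1.4-fold higher number from compound 2 to compound 3 (0.16 log units; within the scatter) expected, though this lies close to the scatter. The estimate for compound 3 in this assay is therefore 45000 nM, with a range from 15000 nM to 120000 nM, and a real chance that only a limit is reported.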

Compound 3, half-maximal inhibitory concentration: 28100 nM
The estimate for compound 3 lay 1.6-fold (0.20 log units) above the measured number; low and high end bracket the measured number.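

Replacing 3,5-dimethylphenyl with 2,5-dimethoxyphenyl on the aromatic nitrogen gave a 1.1-fold lower number from compound 2 to compound 3 (0.05 log units; within the scatter), so this assay does not tell these two rings apart, and a ring carrying alkoxy groups at this position can still give a measurable number. The step with the 4-ethoxyphenyl ring, an at least 1.7-fold lower number from compound 1 to compound 3 (0.25 log units; that floor lies within the scatter), has a floor that does not settle whether the 2,5-dimethoxyphenyl ring truly differs from it, so no rule linking alkoxy groups on this ring to weak activity can be drawn. Compound 1 remains a limit and not a number: the limit of > 50000 nM in this assay, at which 1 of the 3 values shown sits.

The compounds shown leave open whether any change to this aryl ring can move the number beyond the scatter, since all the readable values sit close together at the weak end of the assay. Going by these compounds, it also remains open what this position would give with a ring bearing an amine or a carboxylic acid, or with a plain benzyl group in place of the aryl ring.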